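A few compounds are considered here, and "the series" means these few. Any claim that something is new, unique, unknown or untested is made for them only; others in the source may bear on it.

Measured in a functional assay on HeLa cells (Homo sapiens) for cytotoxicity, read by MTT assay, with a stated time of 24 h; on this read-out lower numbers stand for stronger inhibition and higher numbers for weaker inhibition:
- Compound 1 `CN1C/C(=C\c2ccc(F)cc2)C(=O)/C(=C/c2cccc([N+](=O)[O-])c2)C1`: 6250 nM
- Compound 2 `CN1C/C(=C\c2ccc(Br)cc2)C(=O)/C(=C/c2cccc([N+](=O)[O-])c2)C1`: 11900 nM
- Compound 3 `CN1C/C(=C\c2ccc(C(F)(F)F)cc2)C(=O)/C(=C/c2cccc([N+](=O)[O-])c2)C1`: 3560 nM

In this assay, among the measured compounds shown here, compound 3 stands clear of only one of its two neighbours. The gap to compound 2 is modest but beyond the scatter, at a 3.3-fold lower number from compound 2 to compound 3 (0.52 log units; beyond the scatter). The gap to compound 1 stays within the scatter, at a 1.8-fold lower number from compound 1 to compound 3 (0.24 log units; within the scatter).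

Compound 4 `CN1C/C(=C\c2ccc(C#N)cc2)C(=O)/C(=C/c2ccc(C(F)(F)F)cc2)C1` carries 4-cyanophenyl in place of 3-nitrophenyl on a double-bonded chain carbon bound to a double-bonded ring carbon.

For the measured compounds named here, no measured step touches the 3-nitrophenyl, which all three compounds share, so the data give no direct reading of this exchange. The steps bear on it only indirectly, as a guide to size. They exchange fluoro, bromo and trifluoromethyl on an aromatic carbon, and they are a 1.9-fold higher number from compound 1 to compound 2 (0.28 log units; within the scatter), a 1.8-fold lower number from compound 1 to compound 3 (0.24 log units; within the scatter) and a 3.3-fold lower number from compound 2 to compound 3 (0.52 log units; beyond the scatter). With only these small steps to go on, and none in a known direction for this exchange, no step beyond the scatter is expected in this assay, though the uncertainty is wide. The estimated step is a 1.3-fold higher number from compound 3 to compound 4 (0.10 log units; within the scatter).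

For compound 4 the expected value is 4500 nM, with an estimated range from 1500 nM to 13000 nM.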

Compound 4, half-maximal inhibitory concentration: 3210 nM
Estimate against measurement, compound 4: 1.4-fold (0.15 log units) above; the range from low to high includes it.
By their numbers in this assay, from the lowest: compounds 4, 3, 1 and 2 (each within the scatter of the next, the first and the last beyond it).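

Among the compounds shown here, compound 4 gives the first reading at the position on a double-bonded chain carbon bound to a double-bonded ring carbon, as compounds 1, 2 and 3 all carry 3-nitrophenyl there and differ only in the substituent on their other aromatic ring. In this assay the exchange of 3-nitrophenyl for 4-cyanophenyl gives only a small step (a 1.1-fold lower number from compound 3 to compound 4 (0.04 log units; within the scatter)), so for this pair the nitro group is not needed to keep the read-out at the level of compound 3, and a ring bearing a nitrile serves as well at this position. No measurement at hand offers a reason for this result.

For the compounds shown here, this is a single exchange against a single partner, so it remains open whether 4-cyanophenyl would behave the same way alongside the fluoro or bromo rings of the earlier compounds. On these data alone, it also remains open how far the position tolerates change in this assay once the ring there carries an amine, a carboxylic acid or a longer chain.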